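Replacing 2-hydroxyphenyl with 4-methoxyphenyl in compound 4

This account rests on a few compounds, and the source may have more. Where it says the series, first, only, none or still open, it means among the compounds named here.

Of the compounds shown here, three have been tested in a functional assay on L1210 cells (Mus musculus) for antiproliferative activity, read by MTT assay (on this read-out lower numbers stand for stronger inhibition and higher numbers for weaker inhibition), and none of them has given a number. Compound 1 `COc1ccc(/C=N/NC(=O)c2cn(C3CC3)c3cc(N/N=C/c4ccc(OC)cc4)c(F)cc3c2=O)cc1` reads only as a limit, <= 25000 nM. Compound 2 `O=C(N/N=C/c1ccccc1)c1cn(C2CC2)c2cc(N3CCNCC3)c(F)cc2c1=O` is also a limit, <= 25000 nM. Compound 3 `O=C(N/N=C/c1ccccc1O)c1cn(C2CC2)c2cc(N3CCNCC3)c(F)cc2c1=O`, the starting point here, is likewise only a limit, <= 25000 nM. All that the measurements show is the limit of <= 25000 nM in this assay, at which 3 of the 3 values shown sit.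

Compound 4 `COc1ccc(/C=N/NC(=O)c2cn(C3CC3)c3cc(N4CCNCC4)c(F)cc3c2=O)cc1` is still unmeasured. It carries 4-methoxyphenyl in place of 2-hydroxyphenyl on a carbon with a double bond to nitrogen. Going by the values given here, the one measured step that touches this part of the structure is a step that the two limits leave unreadable from compound 2 to compound 3, where hydroxy replaces hydrogen on an aromatic carbon. That step offers no size to carry over, so no shift beyond the scatter is expected in this assay, and no direction can be favoured. The expected change is a step that the limit leaves unreadable from compound 3 to compound 4. For compound 4 the estimated value is 15000 nM, with an expected range from 4000 nM to 25000 nM.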

Compound 4, half-maximal inhibitory concentration: <= 25000 nM
Compound 4: only a limit was reported; the forecaster's own chance of this, stated with the estimate: 65%; the middle value is on the limit's open side.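

Compound 4 is again only a limit, so no step among compound 1, compound 2, compound 3 and compound 4 can be read in this assay: the limit of <= 25000 nM in this assay, at which 4 of the 4 values shown sit.

The compounds shown leave open how strongly each one acts and whether any of their group changes alters the read-out.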